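Adding methoxy to a compound at the assay limit

The compounds below may be only part of what the source reports. "The series", "measured", "known", "first", "only" and "open" are said of these compounds alone.

Two compounds have been measured so far in a functional assay on MCF7 cells (Homo sapiens) for cytotoxicity, read by MTT assay, with a stated time of 6 days; a higher number here means that more compound is needed for the effect, a lower number that less compound is needed:
- Compound 1 `COC(=O)c1c(-c2ccc(Br)cc2)oc2ccccc2c1=O` gives > 25 ug/mL as a limit
- Compound 2 `COC(=O)c1c(-c2ccc(OCc3ccccc3)cc2)oc2ccccc2c1=O` gives > 25 ug/mL as a limit

Compound 2 stands at > 25 ug/mL in this assay as a limit and not as a number. Among the compounds with values here, the series so far comes down to the limit of > 25 ug/mL in this assay, at which 2 of the 2 values shown sit, and nothing more.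

Compound 3 `COC(=O)c1c(-c2ccc(OCc3ccccc3)cc2)oc2ccc(OC)cc2c1=O` keeps the structure of compound 2 except for methoxy in place of hydrogen on an aromatic carbon of the shared core methoxy in place of hydrogen on an aromatic carbon and nothing else.

Within the data shown here, the only measured step is a step that the two limits leave unreadable from compound 1 to compound 2 and it concerns a different change, so it offers no size to carry over. With compound 2 at the limit of > 25 ug/mL as the sole anchor, no step beyond the usual scatter is expected in either direction in this assay and another limit is the likeliest report. The expected move is a step that the limit leaves unreadable from compound 2 to compound 3 as a rough estimate. Compound 3 is estimated at 35 ug/mL with an expected range from 15 ug/mL to 80 ug/mL for now.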

Compound 3, concentration for half-maximal effect: > 25 ug/mL
Compound 3: only a limit was reported; the forecaster's own chance of this, stated with the estimate: 80%; the middle value lies beyond the limit too.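

Within the data shown here, compound 2 and compound 3 both report only a limit in this assay, so adding methoxy in place of hydrogen gives no step whose size can be read. The compounds shown leave open how much compound any of them needs for the effect, and whether any change to them gives a true number, since the series still offers only this: the limit of > 25 ug/mL in this assay, at which 3 of the 3 values shown sit.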